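Three Cytotoxicity Limits and an Oxadiazole Replacement

The compounds below may be only part of what the source reports. "The series", "measured", "known", "first", "only" and "open" are said of these compounds alone.

Compound 1 `CC(C)Oc1cccc(-c2ccc(C(=O)N(Cc3cccc(OCCCCCC(=O)O)c3)C(C)C)cc2)c1`: in an ADME assay on HEK293 cells (Homo sapiens) for cytotoxicity, read by CellTiter-Glo and resazurin assay, with a stated time of 72 h (a higher number here means that more compound is needed for the effect, a lower number that less compound is needed), compound 1 reaches only the assay limit, > 26000 nM.
Compound 2 `CC(C)N(Cc1cccc(OCCCCCC(=O)O)c1)C(=O)c1ccc(-c2cccc(S(C)(=O)=O)c2)cc1`: in this assay compound 2 likewise stops at the limit, > 26000 nM.
Compound 3 `CCOC(=O)CCCCCOc1cccc(CN(C(=O)c2ccc(-c3cccc4ccccc34)cc2)C(C)C)c1`: in this assay compound 3 also gives no number, only the limit > 26000 nM.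

Compound 3 therefore stands where every measured compound in this set stands: at the limit, not at a number. This is the whole of the evidence, since (the limit of > 26000 nM in this assay, at which 3 of the 3 values shown sit). Among the compounds with values here, the single step between measured compounds that differ in one place, a step that the two limits leave unreadable from compound 1 to compound 2, runs from one limit to another and cannot be read; it concerns a methylsulfonyl in place of isopropoxy and does not touch the part of the molecule changed next.

Compound 4 `CCOC(=O)CCCCCOc1cccc(CN(C(=O)c2ccc(-c3cccc(-c4nnc(C)o4)c3)cc2)C(C)C)c1` differs from compound 3 in one place: 3-(5-methyl-1,3,4-oxadiazol-2-yl)phenyl in place of naphthalen-1-yl on an aromatic carbon. Within the data shown here, no measured step bears on this exchange, and the one step recorded is of unreadable size. Among the measured compounds shown here, the only guide is that all three compounds lie at the limit. Compound 4 is therefore expected to remain there as well, with an estimated step that the limit leaves unreadable from compound 3 to compound 4 that means nothing beyond the scatter. For compound 4 the estimate in this assay is 35000 nM, with a range from 15000 nM to 100000 nM, and most likely the assay will again report only a limit.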

Compound 4, half-maximal effective concentration: > 26000 nM
Compound 4: only a limit was reported; the forecaster's own chance of this, stated with the estimate: 85%; the middle value lies beyond the limit too.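

Compound 4 also gives only a limit, as compound 3 does, so the exchange of naphthalen-1-yl for 3-(5-methyl-1,3,4-oxadiazol-2-yl)phenyl cannot be read as a step. The compounds shown leave open whether any structural change would yield a number in this assay, for all they share is this: the limit of > 26000 nM in this assay, at which 4 of the 4 values shown sit.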